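Bromo in Place of 4-Methoxyphenyl: An Expected Loss

A few compounds are considered here, and "the series" means these few. Any claim that something is new, unique, unknown or untested is made for them only; others in the source may bear on it.

Of the compounds shown here, two have so far been measured in an assay on HEK293 cells for inhibition of Monoacylglycerol lipase ABHD6 (Homo sapiens), read by scintillation counting, with stated times of 30 min and 5 min; on this read-out higher numbers stand for weaker inhibition and lower numbers for stronger inhibition. Compound 1 `Cc1c(-c2ccc(F)cc2)cc(C(=O)NC2CCCCCC2)c(=O)n1Cc1ccc(F)cc1` gives > 10000 nM in this assay, which is a limit of the assay and not a number (the limit of > 10000 nM in this assay, at which 1 of the 2 values shown sits). Going by the values given here, compound 2 `COc1ccc(-c2cc(C(=O)NC3CCCCCC3)c(OCc3ccc(F)cc3)nc2C)cc1` gives 530 nM in this assay and is the only compound with a measured number. Compound 3 `Cc1nc(OCc2ccc(F)cc2)c(C(=O)NC2CCCCCC2)cc1Br` has not yet been measured; it differs from compound 2 by bromo in place of 4-methoxyphenyl on an aromatic carbon. Among the compounds with values here, no step between measured compounds is available to gauge a change of this kind, so the expectation rests on compound 2 alone. Compound 3 is expected to inhibit more weakly than compound 2, beyond the usual scatter. The expected step is a 4.7-fold higher number from compound 2 to compound 3 (0.67 log units; beyond the scatter). Compound 3 is estimated at 2500 nM, between 600 nM and 10000 nM, with a real chance that only a limit is reported.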

Compound 3, half-maximal inhibitory concentration: > 10000 nM
Compound 3 ended at the assay's limit (the forecaster's own chance of this, stated with the estimate: 30%); at least 4.0-fold (0.60 log units) between middle value and limit.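

At this position, para to the (4-fluorobenzyl)oxy group, the change to bromo gives an at least 18-fold higher number from compound 2 to compound 3 (1.27 log units; beyond the scatter) in this assay, the only step shown between compounds that differ in one place. It shows that the measurable inhibition of compound 2 does not survive when 4-methoxyphenyl gives way to this single atom, so a bromo at this position is not an adequate replacement. The step is only a bound and not a number, because compound 3 gives a limit of the assay: the limit of > 10000 nM in this assay, at which 2 of the 3 values shown sit.

The compounds shown leave open whether the methoxy group or the aromatic ring of the 4-methoxyphenyl group accounts for the difference, which a plain phenyl at this position could separate. They also leave open how a pyridine ring or a morpholine there would read in this assay.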